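The source may report more compounds than this note shows. Statements on the series, on what has been measured and on what is new or still open speak of the compounds shown alone.

Working notes on the series. In a functional assay on CEM-SS cells (Homo sapiens) for cytotoxicity (a higher number here means a weaker inhibitor, a lower number a stronger inhibitor), compound 1 `Nc1nc2cc(Cl)c(Cl)cc2n1Cc1ccc(Cl)cc1` gives 32000 nM, compound 2 `COc1ccc(Cn2c(N)nc3cc(Cl)c(Cl)cc32)cc1` gives 27000 nM and compound 3 `Cc1ccc(Cn2c(N)nc3cc(Cl)c(Cl)cc32)cc1` gives 40000 nM. Compound 2 stands within the scatter of both other compounds, as shown by a 1.2-fold lower number from compound 1 to compound 2 (0.07 log units; within the scatter) and a 1.5-fold higher number from compound 2 to compound 3 (0.17 log units; within the scatter). The remaining pair agrees, with a 1.3-fold higher number from compound 1 to compound 3 (0.10 log units; within the scatter).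

Next is compound 4 `COc1ccc(Cn2c(Cl)nc3cc(Cl)c(Cl)cc32)cc1`, which differs from compound 2 by chloro in place of amino on an aromatic carbon. This is chloro in place of amino on an aromatic carbon, between two ring nitrogen atoms.

The three measured steps only exchange chloro, methoxy and methyl on an aromatic carbon elsewhere in the molecule. None of them replaces the amino group, so they bear on this change only indirectly, and the data give no direct guide to it. They do show numbers in this assay that stay within the scatter across the series, so no step beyond the scatter is expected, in either direction. The estimated step is a 1.2-fold lower number from compound 2 to compound 4 (0.09 log units; within the scatter). For compound 4 the estimate is 22000 nM, with an expected range from 7000 nM to 65000 nM.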

Compound 4, half-maximal inhibitory concentration: > 100000 nM
Compound 4 gave a limit, no number (the forecaster's own chance of this, stated with the estimate: 20%); at least 4.5-fold (0.65 log units) between middle value and limit.
By their numbers in this assay, from the lowest: compounds 2, 1 and 3 (each within the scatter of the next). At a limit, above all of these: compound 4.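

In this assay compound 4 gives > 100000 nM, which is a limit of the assay and not a number. Chloro in place of amino on this aromatic carbon, between two ring nitrogen atoms, gives an at least 3.7-fold higher number from compound 2 to compound 4 (0.56 log units; beyond the scatter), the only step in the series beyond the scatter, whereas the exchanges of chloro, methoxy and methyl elsewhere in the molecule all stayed within it. This position therefore responds to a change in this assay in a way the earlier compounds did not reveal, and the true size of the step remains undefined: the limit of > 100000 nM in this assay, at which 1 of the 4 values shown sits.

As far as these compounds go, whether a methylamino, hydroxyl or methyl group on this carbon would keep the number close to that of compound 2 remains open. Also open is whether the same exchange gives a similar step when the methoxy group is replaced by chloro or methyl, since only the methoxy pair is shown.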